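The source may hold more compounds than are shown below. What is called first, only, known or untested is meant among the compounds shown, and "the series" means these compounds.

Working notes on the series. In a functional assay on A549 cells (Homo sapiens) for inhibition, read by sulforhodamine B assay, with a stated time of 72 h (on this read-out higher numbers stand for weaker inhibition of growth and lower numbers for stronger inhibition of growth), compound 1 (`CNC(=O)/C=C/c1ccncc1-c1ccc2ccccc2c1`) gives 6620 nM and compound 2 (`CCOC(=O)/C=C/c1ccncc1-c1ccc2[nH]ccc2c1`) gives 7440 nM and these two values stand within the scatter of each other. Compound 3 (`O=C(O)/C=C/c1ccncc1-c1ccc2ccccc2c1`) differs from compound 1 by hydroxy in place of methylamino on a carbonyl carbon. Going by the values given here, no measured pair shows this change, so the expectation rests on the structural change alone: a step beyond the scatter towards a higher number in this assay and so weaker inhibition of growth. The estimated step is a 3.0-fold higher number from compound 1 to compound 3 (0.48 log units; beyond the scatter) on this reasoning. For compound 3 the estimated value is 20000 nM with an expected range from 7000 nM to 60000 nM as its bounds.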

Compound 3, concentration for 50% growth inhibition: > 10000 nM
Compound 3: only a limit was reported; the forecaster's own chance of this, stated with the estimate: 20%; the middle value is on the limit's open side.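

Going by these compounds alone, on the carbonyl carbon whose other neighbour is the double-bonded chain carbon, hydroxy in place of methylamino is the first change read at this place. In this assay compound 3 gives > 10000 nM and that value is a limit of the assay, not a number. The change reads as an at least 1.5-fold higher number from compound 1 to compound 3 (0.17 log units; that floor lies within the scatter) and this shows no stronger inhibition of growth with carboxy here, yet the step is only a floor: the limit of > 10000 nM in this assay, at which 1 of the 3 values shown sits.

On these data alone, whether the true step lies beyond the scatter stays open. Also open, as far as these compounds go, is how a methoxy or dimethylamino group on this carbonyl carbon would read against the methylamino of compound 1.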